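The source may hold more compounds than are shown below. What is called first, only, known or untested is meant among the compounds shown, and "the series" means these compounds.

Measured so far in a functional assay on CCRF-CEM cells (Homo sapiens) for cytotoxicity, read by cell counting, with a stated time of 3 days; on this read-out higher numbers stand for weaker inhibition and lower numbers for stronger inhibition:
compound 1 `C=C(Br)C(=O)Nc1cccc(/C=C2\SC(=O)N(Cc3ccc(C)cc3)C2=O)c1`, 1200 nM
compound 2 `C=C(Br)C(=O)Nc1cccc(/C=C2\SC(=O)N(Cc3cccc(Cl)c3)C2=O)c1`, 1400 nM
compound 3 `Nc1cccc(/C=C2\SC(=O)N(Cc3ccc(C(F)(F)F)cc3)C2=O)c1`, > 250000 nM

Compound 3 stands apart from the others: in this assay it gives only > 250000 nM, which is a limit of the measurement rather than a number, so its true value is not known (the limit of > 250000 nM in this assay, at which 1 of the 3 values shown sits). Compounds 1 and 2 both carry a (1-bromoethenyl)carbonyl group on the aromatic nitrogen, and both give numbers in this assay; compound 3 lacks that group and gives a limit.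

Compound 4 `C=C(Br)C(=O)Nc1cccc(/C=C2\SC(=O)N(Cc3ccc(C(F)(F)F)cc3)C2=O)c1` is compound 3 with this difference: (1-bromoethenyl)carbonyl in place of hydrogen on a nitrogen on an aromatic ring. Within the data shown here, the only measured step, a 1.2-fold higher number from compound 1 to compound 2 (0.07 log units; within the scatter), swaps the ring attached to the saturated carbon, not the group on the aromatic nitrogen, so it does not test the present change directly; it shows only that the ring on that side makes little difference. Compound 4 therefore ends up with the same amide as compound 1, differing only in the ring on the saturated carbon, where compound 1 gives 1200 nM and compound 2 gives 1400 nM.

In this assay compound 4 is expected to give 1300 nM, in the range 400 nM to 4500 nM. The step is thus expected to read an at least 190-fold lower number from compound 3 to compound 4 (2.28 log units; beyond the scatter).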

Compound 4, half-maximal inhibitory concentration: 920 nM
The estimate for compound 4 lay 1.4-fold (0.15 log units) above the measured number; the range from low to high includes it.
By their numbers in this assay, from the lowest: compounds 4, 1 and 2 (each within the scatter of the next). At a limit, above all of these: compound 3.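

In this assay, among these compounds, setting (1-bromoethenyl)carbonyl in place of hydrogen on a nitrogen on an aromatic ring gives an at least 270-fold lower number from compound 3 to compound 4 (2.43 log units; beyond the scatter), the first direct pair to link this group to a large step in the read-out. The value of compound 3 is a limit and not a number, so the true size of that step stays unknown: the limit of > 250000 nM in this assay, at which 1 of the 4 values shown sits.

With the amide in place, the ring on the saturated carbon does not separate the compounds: 4-(trifluoromethyl)phenyl in place of 3-chlorophenyl gives a 1.5-fold lower number from compound 2 to compound 4 (0.18 log units; within the scatter), and trifluoromethyl in place of methyl on an aromatic carbon gives a 1.3-fold lower number from compound 1 to compound 4 (0.12 log units; within the scatter), both within the scatter.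

The compounds shown leave open which part of the new group carries the step, since a plain acetyl group or a propenoyl group without the bromine on the same nitrogen would separate the bromine and the double bond from the amide itself. Going by these compounds, the effect of the group also rests on a single pair, so it remains open whether the free amino counterparts of compound 1 and compound 2 would also sit at a limit.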